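This account rests on a few compounds, and the source may have more. Where it says the series, first, only, none or still open, it means among the compounds named here.

Measured so far:
compound 1 `O=C(NNc1ccnc2cc(Cl)ccc12)c1ccccc1/N=C/c1ccc(Cl)cc1`, 5.62
compound 2 `CN(C)c1ccc(/C=N/c2ccccc2C(=O)NNc2ccnc3cc(Cl)ccc23)cc1`, 5.03

In a physicochemical assay for lipophilicity, measured as octanol-water partition (on this read-out higher numbers stand for higher lipophilicity and lower numbers for lower lipophilicity), compound 1 stands highest of the two numbers; its nearest neighbour is compound 2, and the step is a number 0.59 log units lower from compound 1 to compound 2 (beyond the scatter), beyond the scatter. Compound 3 `O=C(NNc1ccnc2cc(Cl)ccc12)c1ccccc1/N=C/c1ccncc1` has not yet been measured. Its difference from compound 1 is pyridin-4-yl in place of 4-chlorophenyl on a carbon with a double bond to nitrogen. Among the measured compounds shown here, no measured step covers this exchange directly. For the measured compounds named here, the only step in hand, dimethylamino in place of chloro on an aromatic carbon, was a number 0.59 log units lower from compound 1 to compound 2 (beyond the scatter); it shares with the present change the loss of the chloro group, but the entering group differs, so it can serve only as a rough guide to the direction. A downward step in this assay beyond the scatter is expected for compound 3, estimated as a number 1.72 log units lower from compound 1 to compound 3 (beyond the scatter). The value of compound 3 in this assay is therefore estimated at 3.9, with a range from 3.3 to 4.6.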

Compound 3, partition coefficient: 3.86
Beside the measured number, compound 3's estimate is 0.04 log units above it, within the range that was stated.
By their numbers in this assay, from the lowest: compound 3; then compound 2; then compound 1.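

In this assay, among the compounds shown here, the whole aromatic ring on the carbon with a double bond to nitrogen is exchanged for the first time, and pyridin-4-yl in place of 4-chlorophenyl gives a large step (a number 1.76 log units lower from compound 1 to compound 3 (beyond the scatter)). Pyridin-4-yl in place of 4-(dimethylamino)phenyl at the same place is also large (a number 1.17 log units lower from compound 2 to compound 3 (beyond the scatter)), and both exceed the earlier exchange on the phenyl ring alone (a number 0.59 log units lower from compound 1 to compound 2 (beyond the scatter)), which leaves compound 3 lowest of the three. No measurement in hand accounts for the size of these steps.

Open, on these data alone, is how pyridin-3-yl or pyridin-2-yl would stand at this place in this assay. Also open, as far as these compounds go, is where a phenyl ring carrying a methoxy group or a carboxylic acid would fall relative to compound 2 and compound 3.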